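This account rests on a few compounds, and the source may have more. Where it says the series, first, only, none or still open, it means among the compounds named here.

Going by the values given here, compound 3 `O=C(CCCCCCCCCc1ccccc1)CC(=O)N[C@H]1CCOC1=O` stands second highest of the three numbers measured so far: in a functional assay on NCI-H630 cells (Homo sapiens) for cytotoxicity, read by sulforhodamine B assay, with a stated time of 5 days (a lower number here means a stronger inhibitor, a higher number a weaker inhibitor), compound 3 gives 16000 nM, while compound 2 `O=C(CCCCCCCCc1ccccc1)CC(=O)N[C@H]1CCOC1=O` gives 11000 nM and compound 1 `O=C(CCCCCCCCCCc1ccccc1)CC(=O)N[C@H]1CCOC1=O` gives 23000 nM. Compound 4 `O=C(CCCCCCCCCCCc1ccccc1)CC(=O)N[C@H]1CCOC1=O` carries the change (phenethyl in place of phenyl on a saturated chain carbon, nine bonds along the chain from a carbonyl carbon). Among the compounds with values here, two measured steps bear on it. Within the data shown here, the change a 2.1-fold lower number from compound 1 to compound 2 (0.32 log units; beyond the scatter) trims the chain by two carbons at the same kind of position and is the only step here that clears the scatter; the change a 1.4-fold lower number from compound 1 to compound 3 (0.16 log units; within the scatter) and the change a 1.5-fold higher number from compound 2 to compound 3 (0.16 log units; within the scatter) both stay within it. Taken together the numbers rise as the chain grows, and compound 4 extends that chain further still, so a modest rise in this assay is expected, of the order a 1.9-fold higher number from compound 3 to compound 4 (0.27 log units; within the scatter), though a step within the scatter cannot be excluded on three data points. Compound 4 is therefore estimated at 30000 nM, with a range from 15000 nM to 60000 nM.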

Compound 4, half-maximal inhibitory concentration: 33000 nM
Compound 4: middle estimate off by 1.1-fold (0.04 log units), on the low side; the measured number falls inside the stated range.
By their numbers in this assay, from the lowest: compounds 2, 3, 1 and 4 (each within the scatter of the next, the first and the last beyond it).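

In this assay, the swap of phenyl for phenethyl on a saturated chain carbon, nine bonds along the chain from a carbonyl carbon, gives a 2.1-fold higher number from compound 3 to compound 4 (0.31 log units; beyond the scatter), and the shortest and longest chains shown lie furthest apart, with a 3.0-fold higher number from compound 2 to compound 4 (0.48 log units; beyond the scatter), while a 1.4-fold higher number from compound 1 to compound 4 (0.16 log units; within the scatter) stays within the scatter. Phenyl in place of phenethyl now reads as a repeatable step on two cores, no longer a single observation: the same change on two cores in this assay, a 2.1-fold lower number (0.32 log units; beyond the scatter) from compound 1 to compound 2 and a 2.1-fold lower number (0.31 log units; beyond the scatter) from compound 4 to compound 3, 1.0-fold (0.01 log units) apart, within the scatter of two such steps. The smaller change of benzyl in place of phenyl also repeats, though each of its steps stays within the scatter: the same change on two cores in this assay, a 1.5-fold higher number (0.16 log units; within the scatter) from compound 2 to compound 3 and a 1.4-fold higher number (0.16 log units; within the scatter) from compound 1 to compound 4, 1.0-fold (0.01 log units) apart, within the scatter of two such steps.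

The compounds shown leave open whether a chain shorter than in compound 2 or longer than in compound 4 would continue this trend. They also leave open how an amine or a carboxylic acid in place of the phenyl would read in this assay.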